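A few compounds are considered here, and "the series" means these few. Any claim that something is new, unique, unknown or untested is made for them only; others in the source may bear on it.

Compound 1 `Cc1csc(N/N=C/c2ccc(Cl)cc2Cl)n1` and compound 2 `Clc1ccc(/C=N/Nc2nc(-c3ccccc3)cs2)c(Cl)c1` share a core; in an assay on mitochondria for inhibition of Amine oxidase [flavin-containing] A (Bos taurus) (a higher number here means a weaker inhibitor, a lower number a stronger inhibitor), compound 1 gives 12 nM and compound 2 gives 93.3 nM. The change between them, (phenyl in place of methyl on an aromatic carbon), gave a 7.8-fold higher number from compound 1 to compound 2 (0.89 log units; beyond the scatter). Compound 3 `Cc1csc(/N=C/c2ccccc2C)n1` has a different core, and the difference between the two cores is not broken down here; in this assay compound 3 gives 35.5 nM. Compound 4 `Cc1ccccc1/C=N/c1nc(-c2ccccc2)cs1` differs from compound 3 by phenyl in place of methyl on an aromatic carbon, the same kind of change, though here the place is two ring bonds from the ring atom that bears a group of 9 heavy atoms, where before it bore a large group. Resting on the step of a 7.8-fold higher number from compound 1 to compound 2 (0.89 log units; beyond the scatter), compound 4 is expected to show a weakening step of about a 7.0-fold higher number from compound 3 to compound 4 (0.85 log units; beyond the scatter) in this assay. Compound 4 is therefore estimated at 250 nM, likely between 80 nM and 800 nM.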

Compound 4, inhibition constant: 66.1 nM
Compound 4: the middle estimate sits 3.8-fold (0.58 log units) above what was measured; measured number below the stated range.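

In this assay, phenyl in place of methyl gave a 1.9-fold higher number from compound 3 to compound 4 (0.27 log units; within the scatter), so the size of the step did not carry over from the core of compound 1 to the core of compound 3: the same change on two cores in this assay, a 7.8-fold higher number (0.89 log units; beyond the scatter) from compound 1 to compound 2 and a 1.9-fold higher number (0.27 log units; within the scatter) from compound 3 to compound 4, 4.2-fold (0.62 log units) apart, beyond the scatter of two such steps

This shows that, in these two pairs, the size of the step depends on the core, and that a step read on one core is a poor guide to the other. It does not show which part of the cores accounts for the gap, and two pairs set no rule for the series.

From the compounds shown here alone, whether an amine, a carboxylic acid or a longer chain in place of methyl on that aromatic carbon would also differ between the two cores stays open. So does how the change would behave on any further core.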